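The compounds below may be only part of what the source reports. "The series", "measured", "known", "first", "only" and "open" are said of these compounds alone.

The series rests on compound 1, `O=C(NCCNS(=O)(=O)c1sccc1-c1ccccc1Oc1ccc(O)c(O)c1)Nc1cc(Cl)cc(Cl)c1`, which carries a catechol ether and a dichlorophenyl urea. In a functional assay on HeLa cells (Homo sapiens) for inhibition, read by CCK-8 assay, with a stated time of 48 h (on this read-out higher numbers stand for weaker inhibition and lower numbers for stronger inhibition), compound 1 gives only a limit, > 50000 nM. Compound 2, `CC(C)c1ccc(Oc2ccc(O)c(O)c2)c(-c2ccsc2S(=O)(=O)NCCNC(=O)Nc2cc(Cl)cc(Cl)c2)c1`, differs by isopropyl in place of hydrogen on an aromatic carbon. In this assay compound 2 likewise gives only a limit, > 50000 nM. The resulting step that the two limits leave unreadable from compound 1 to compound 2 cannot be read. Compound 3, `O=C(NCCNS(=O)(=O)c1sccc1-c1ccccc1Oc1ccc(O)c(O)c1)Nc1cc(C(F)(F)F)cc(C(F)(F)F)c1`, carries a bis(trifluoromethyl)phenyl urea instead; how its core differs from that of compound 1 is not broken down here. In this assay compound 3 gives only a limit, > 50000 nM. Compound 4, `CC(C)c1ccc(Oc2ccc(O)c(O)c2)c(-c2ccsc2S(=O)(=O)NCCNC(=O)Nc2cc(C(F)(F)F)cc(C(F)(F)F)c2)c1`, is reached from compound 3 by isopropyl in place of hydrogen on an aromatic carbon, the same change as from compound 1 to compound 2. Going by the values given here, since the limit of > 50000 nM in this assay, at which 3 of the 3 values shown sit, is where every value so far sits, the step of a number no higher from compound 3 to compound 4 (the limit leaves the size open) is expected to remain unreadable as well, and compound 4 is estimated to give 50000 nM in this assay, most probably again only as a limit.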

Compound 4, half-maximal inhibitory concentration: > 50000 nM
Compound 4 ended at the assay's limit; the forecaster's own chance of this, stated with the estimate: 90%; the middle value sits exactly at the limit.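

The step from compound 3 to compound 4 cannot be read, because both stand only at a limit: the limit of > 50000 nM in this assay, at which 4 of the 4 values shown sit.

The compounds shown leave open how strongly any of them inhibits in this assay, and whether isopropyl in place of hydrogen changes that.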